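From bromo to trifluoromethyl: expecting a weaker number

A few compounds are considered here, and "the series" means these few. Any claim that something is new, unique, unknown or untested is made for them only; others in the source may bear on it.

Of the compounds shown here, three have so far been measured in an assay on isolated protein for inhibition of Amine oxidase [flavin-containing] B (Homo sapiens), read by Amplex Red, with a stated time of 15 min; on this read-out lower numbers stand for stronger inhibition and higher numbers for weaker inhibition. Compound 1 `CC(=O)c1ccc(OCc2ccccc2Cl)cc1` gives 311 nM, compound 2 `CC(=O)c1cccc(OCc2cccc(Cl)c2)c1` gives 34.2 nM, and compound 3 `CC(=O)c1cccc(OCc2cccc(Br)c2)c1` gives 96.3 nM. Compound 3 thus stands second highest of the three numbers, closer to compound 2 than to compound 1. Compound 4 `CC(=O)c1cccc(OCc2cccc(C(F)(F)F)c2)c1` differs from compound 3 by trifluoromethyl in place of bromo on an aromatic carbon. Among the compounds with values here, the one measured step that bears on this change is a 2.8-fold higher number from compound 2 to compound 3 (0.45 log units; beyond the scatter), in which the halogen with more heavy atoms gave the higher number. Because compound 3 already sits at 96.3 nM after that exchange, compound 4 is expected to move further in the same direction, with an expected step of a 1.9-fold higher number from compound 3 to compound 4 (0.27 log units; within the scatter). Compound 4 is therefore estimated at 180 nM, with a range from 60 nM to 550 nM.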

Compound 4, half-maximal inhibitory concentration: 21.2 nM
For compound 4 the middle estimate is 8.5-fold (0.93 log units) above the measured one; measured number below the stated range.
By their numbers in this assay, from the lowest: compounds 4 and 2 (each within the scatter of the next); then compound 3; then compound 1.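

In this assay, trifluoromethyl on this aromatic carbon gives a 4.5-fold lower number from compound 3 to compound 4 (0.66 log units; beyond the scatter), so four heavy atoms in place of the single bromine did not raise the number, unlike the change of a 2.8-fold higher number from compound 2 to compound 3 (0.45 log units; beyond the scatter). With a 1.6-fold lower number from compound 2 to compound 4 (0.21 log units; within the scatter), inside the scatter, trifluoromethyl and chloro cannot be told apart at this place. No measurement at hand accounts for the difference between bromo and trifluoromethyl. Open, on these data alone, is how an amine, a carboxylic acid or a methoxy group would fare on this carbon, and whether trifluoromethyl would give a similar number on the core of compound 1.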